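The source may report more compounds than this note shows. Statements on the series, on what has been measured and on what is new or still open speak of the compounds shown alone.

Measured so far in a functional assay on A549 cells (Homo sapiens) for inhibition, read by CCK-8 assay, with a stated time of 72 h, tested at 10 uM; a higher number here means more inhibition of growth at the concentration tested, a lower number less inhibition of growth: compound 1 `CN(C)C(=O)c1cc2cnc(Nc3ccc(NC(=O)C4(C(=O)Nc5cccc(C(F)(F)F)c5)CC4)cc3)nc2n1C1CCCC1`, 89.2%; compound 2 `COC(=O)c1ccc(NC(=O)C2(C(=O)Nc3ccc(Nc4ncc5cc(C(=O)N(C)C)n(C6CCCC6)c5n4)cc3)CC2)cc1`, 92%; compound 3 `COc1cccc(NC(=O)C2(C(=O)Nc3ccc(Nc4ncc5cc(C(=O)N(C)C)n(C6CCCC6)c5n4)cc3)CC2)c1`, 96%.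

Compound 1 differs from compound 2 by a number 2.8 percentage points higher from compound 1 to compound 2 (within the scatter) and from compound 3 by a number 6.8 percentage points higher from compound 1 to compound 3 (within the scatter); neither gap exceeds the scatter, and compound 2 against compound 3 likewise gives a number 4 percentage points higher from compound 2 to compound 3 (within the scatter). All three numbers are therefore indistinguishable here.

Compound 4 `CN(C)C(=O)c1cc2cnc(Nc3ccc(NC(=O)C4(C(=O)Nc5cccc(C#N)c5)CC4)cc3)nc2n1C1CCCC1` is not yet measured. Relative to compound 1 the change is cyano in place of trifluoromethyl on an aromatic carbon. The two steps that bear on it, both exchanges of the same aryl group on an amide-type nitrogen of compound 1, stayed within the scatter, so no step beyond the scatter is expected in this assay for compound 4 either. Compound 4 is estimated at 91% (range 82% to 97%), an expected step of a number 1.8 percentage points higher from compound 1 to compound 4 (within the scatter).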

Compound 4, percent growth inhibition at one concentration: 73.6%
Estimate against measurement, compound 4: 17.4 percentage points above; the measured number lies below the stated range.
By their numbers in this assay, from the lowest: compound 4; then compounds 1, 2 and 3 (each within the scatter of the next).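

In this assay, among the compounds shown here, this aromatic carbon is not indifferent to its substituent: cyano in place of trifluoromethyl gives a number 15.6 percentage points lower from compound 1 to compound 4 (beyond the scatter) and is the first exchange here to pass the scatter. The gap holds against the other two aryl groups, with a number 22.4 percentage points lower from compound 3 to compound 4 (beyond the scatter) and also a number 18.4 percentage points lower from compound 2 to compound 4 (beyond the scatter), so 3-cyanophenyl alone stands apart from three aryl groups within the scatter of each other. No measurement here accounts for this gap. From the compounds shown here alone, whether an amine or a carboxylic acid on the same carbon would fall with the nitrile or stay with the other three remains open.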